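A few compounds are considered here, and "the series" means these few. Any claim that something is new, unique, unknown or untested is made for them only; others in the source may bear on it.

In an assay on isolated protein for inhibition of alkaline phosphatase, tissue-nonspecific isozyme (Homo sapiens) (a lower number here means a stronger inhibitor, a higher number a weaker inhibitor), compound 1 `COc1ccc(Cl)cc1S(=O)(=O)Nc1cncc(-c2ccccc2C)c1` gives 178 nM, the highest of the three numbers recorded so far. Compound 2 `COc1ccc(Br)cc1S(=O)(=O)Nc1cccnc1` gives 43 nM in this assay, and compound 3 `COc1ccc(Cl)cc1S(=O)(=O)Nc1cnc2ccccc2c1` gives 6 nM, both lower than compound 1 by margins beyond the scatter. Compound 4 `COc1ccc(Cl)cc1S(=O)(=O)Nc1cncc(-c2ccncc2)c1` has not yet been measured. It differs from compound 1 by pyridin-4-yl in place of 2-methylphenyl on an aromatic carbon. Among the compounds with values here, no measured pair shows this change, so the expectation rests only on the spread of the three values and on compound 1 as the starting point. The step of a 1.2-fold lower number from compound 1 to compound 4 (0.07 log units; within the scatter) is expected to be small, not clearly beyond the scatter in either direction. Compound 4 is therefore estimated to give 150 nM in this assay, with a range from 40 nM to 600 nM.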

Compound 4, half-maximal inhibitory concentration: 73 nM
For compound 4 the middle estimate is 2.1-fold (0.31 log units) above the measured one; measured number inside the range.
By their numbers in this assay, from the lowest: compound 3; then compounds 2 and 4 (each within the scatter of the next); then compound 1.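

In this assay, pyridin-4-yl in place of 2-methylphenyl gives a 2.4-fold lower number from compound 1 to compound 4 (0.39 log units; beyond the scatter) at this position, two atoms from the ring nitrogen. Within the data shown here, this is the first step read at this position, and it shows that a ring with one nitrogen and one hydrogen-bond acceptor can replace the carbon-only ring with a modest change in the number. No evidence at hand bears on what lies behind this step. From the compounds shown here alone, how an unsubstituted phenyl or a pyridin-3-yl would stand here remains open, so the effects of adding the ring nitrogen and losing the methyl cannot yet be told apart.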